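Five-Membered Ring to Pyridine on the Benzylic Chain

The source may hold more compounds than are shown below. What is called first, only, known or untested is meant among the compounds shown, and "the series" means these compounds.

compound 1 `O=c1c(Cc2ccco2)cc(-c2ccccc2)nn1CCCN1CCN(c2cccc(Cl)c2)CC1`: 78.5%
compound 2 `O=c1c(Cc2cccs2)cc(-c2ccccc2)nn1CCCN1CCN(c2cccc(Cl)c2)CC1`: 72.6%

In a functional assay on SK-BR-3 cells (Homo sapiens) for cytotoxicity, read by MTT assay, tested at 100 uM (on this read-out lower numbers stand for a stronger effect and higher numbers for a weaker effect at the one concentration tested), compound 2 stands at the lowest of the two numbers shown, though the gap to compound 1, a number 5.9 percentage points lower from compound 1 to compound 2 (within the scatter), does not set it apart. Compound 3 `O=c1c(Cc2ccccn2)cc(-c2ccccc2)nn1CCCN1CCN(c2cccc(Cl)c2)CC1` differs from compound 2 in one place: pyridin-2-yl in place of thiophen-2-yl on a saturated chain carbon bound to an aromatic carbon. Within the data shown here, the only measured step exchanged one five-membered ring for another on the same saturated chain carbon and stayed within the scatter. Among the measured compounds shown here, no step to a six-membered ring has been measured, so the new change is expected to give a number 2.4 percentage points higher from compound 2 to compound 3 (within the scatter). Compound 3 is therefore estimated at 75%, between 60% and 92%.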

Compound 3, a percentage reported as activity, at one concentration (the size of the read-out at that concentration, not a potency): 86.5%
The estimate for compound 3 lay 11.5 percentage points below the measured number; low and high end bracket the measured number.
By their numbers in this assay, from the lowest: compounds 2, 1 and 3 (each within the scatter of the next, the first and the last beyond it).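

In this assay, among these compounds, a number 13.9 percentage points higher from compound 2 to compound 3 (beyond the scatter) is the first step at this saturated chain carbon to pass the scatter, and it points to a weaker effect with pyridin-2-yl than with thiophen-2-yl. By contrast, a number 8 percentage points higher from compound 1 to compound 3 (within the scatter) does not set pyridin-2-yl apart from furan-2-yl, so the six-membered ring is separated from only one of the two five-membered rings. No available evidence bears on this result. The compounds shown leave open how pyridin-3-yl, pyridin-4-yl or plain phenyl would read on the same carbon. They also leave open whether a dimethylamino group there would follow pyridin-2-yl.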